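The compounds below may be only part of what the source reports. "The series", "measured", "known", "first", "only" and "open" are said of these compounds alone.

In a functional assay on MGC-803 cells (Homo sapiens) for antiproliferative activity, read by MTT assay (on this read-out higher numbers stand for weaker inhibition and lower numbers for stronger inhibition), three compounds have been measured:
compound 1, `COc1cc2ncnc(NCc3cccc(NC(=O)Nc4ccccc4)c3)c2cc1OC`, 10000 nM
compound 2, `COc1cc2ncnc(NCc3cccc(NC(=O)Nc4cccc(C)c4)c3)c2cc1OC`, 44600 nM
compound 3, `COc1cc2ncnc(NCc3cccc(NC(=O)Nc4ccc(C)cc4)c3)c2cc1OC`, 34200 nM

Compound 3 stands second highest of these three numbers. Its nearest neighbour is compound 2, from which a 1.3-fold lower number from compound 2 to compound 3 (0.12 log units; within the scatter), a gap within the scatter; its furthest is compound 1, from which a 3.4-fold higher number from compound 1 to compound 3 (0.53 log units; beyond the scatter). Compound 4, `COc1ccccc1NC(=O)Nc1cccc(CNc2ncnc3cc(OC)c(OC)cc23)c1`, differs from compound 3 by 2-methoxyphenyl in place of 4-methylphenyl on an amide-type nitrogen. Among the compounds with values here, no measured step exchanges the ring on the amide-type nitrogen for a methoxy-bearing ring. The two steps that touch that ring, a 4.5-fold higher number from compound 1 to compound 2 (0.65 log units; beyond the scatter) and a 3.4-fold higher number from compound 1 to compound 3 (0.53 log units; beyond the scatter), show that a methyl on it gives a modestly higher number than the unsubstituted ring, while a 1.3-fold lower number from compound 2 to compound 3 (0.12 log units; within the scatter) lies within the scatter. A methoxy group has not been tested anywhere in this set, so the direction of the step from the methyl-bearing to the methoxy-bearing ring cannot be read from these numbers. In this assay the step expected is therefore a 1.1-fold lower number from compound 3 to compound 4 (0.06 log units; within the scatter), that is, nothing beyond the scatter. Compound 4 is accordingly estimated at 30000 nM in this assay, with an expected range from 10000 nM to 100000 nM.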

Compound 4, half-maximal inhibitory concentration: 7710 nM
Compound 4: the middle estimate sits 3.9-fold (0.59 log units) above what was measured; measured number below the stated range.
By their numbers in this assay, from the lowest: compounds 4 and 1 (each within the scatter of the next); then compounds 3 and 2 (each within the scatter of the next).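

In this assay, the ring on the amide-type nitrogen turns out to accept a substituent without the shift that both methyl groups produced: methoxy in place of hydrogen gives a 1.3-fold lower number from compound 1 to compound 4 (0.11 log units; within the scatter) and so does not separate the 2-methoxyphenyl compound from the unsubstituted phenyl compound. Set against the methyl-bearing rings, the same 2-methoxyphenyl ring gives a 4.4-fold lower number from compound 3 to compound 4 (0.65 log units; beyond the scatter) and a 5.8-fold lower number from compound 2 to compound 4 (0.76 log units; beyond the scatter) on this read-out, so among these four compounds a substituent on this ring does not by itself bring a higher number, and the outcome depends on which substituted ring is present. Both of these steps change the group and its place on the ring at once, so neither can be credited to methoxy alone, and nothing available here accounts for the difference between the methoxy-bearing and methyl-bearing rings.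

As far as these compounds go, what remains open is whether methoxy would give the same result at another place on this ring, and whether a methyl group would follow it there. From the compounds shown here alone, it is also open how this position would respond to a chlorine atom, a trifluoromethyl group or a longer ether such as ethoxy.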